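The source may hold more compounds than are shown below. What is called first, only, known or untested is meant among the compounds shown, and "the series" means these compounds.

Measured in a functional assay on LNCaP cells (Homo sapiens) for cytotoxicity; a lower number here means a stronger inhibitor, a higher number a weaker inhibitor:
- compound 1 `CNC(=O)Nc1ccc(-c2nc(N3CC4CCC(C3)O4)c3cnn(CCN(C)C)c3n2)cc1` gives 400 nM
- compound 2 `CNC(=O)Nc1ccc(-c2nc(N3CC4CCC(C3)O4)c3cnn(CCO)c3n2)cc1` gives 650 nM
- compound 3 `CNC(=O)Nc1ccc(-c2nc(N3CC4CCC(C3)O4)c3cnn([C@H]4CC[C@@H](O)CC4)c3n2)cc1` gives 20 nM

Compound 3 has the lowest number of the three, and its steps to both others lie beyond the scatter. All three share one core and differ only in the group on an aromatic nitrogen.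

Compound 4 `CNC(=O)Nc1ccc(-c2nc(N3CC4CCC(C3)O4)c3cnn(C4CCC5(CC4)OCCCO5)c3n2)cc1` keeps the shared core and changes that group: a group of 11 heavy atoms (9 carbon, 2 oxygen; one six-membered non-aromatic ring of carbon only, one six-membered non-aromatic ring with 2 hetero atoms) in place of a group of 7 heavy atoms (6 carbon, 1 oxygen; one six-membered non-aromatic ring of carbon only), on an aromatic nitrogen. The six-membered non-aromatic ring of carbon only stays, while a six-membered non-aromatic ring with 2 hetero atoms enters and the hydroxy group of the 4-hydroxycyclohexyl goes.

Three measured steps offer guidance. Two are large and both end on the ring-bearing compound: a 20-fold lower number from compound 1 to compound 3 (1.30 log units; beyond the scatter) and a 33-fold lower number from compound 2 to compound 3 (1.51 log units; beyond the scatter). The third, a 1.6-fold higher number from compound 1 to compound 2 (0.21 log units; within the scatter), lies within the scatter. Compound 4 retains the carbon ring shared with compound 3, so a collapse to the level of compound 1 and compound 2 seems unlikely. Going by the values given here, still, no measured compound tests removing the hydroxy group from that ring or adding a second ring there, so some loss remains plausible.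

The expected change is modest and upward, a 2.5-fold higher number from compound 3 to compound 4 (0.40 log units; beyond the scatter), and this estimate is uncertain. For compound 4 the estimated value is 50 nM, with an expected range from 12 nM to 220 nM.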

Compound 4, half-maximal inhibitory concentration: 8 nM
For compound 4 the middle estimate is 6.3-fold (0.80 log units) above the measured one; the whole stated range lies above it.
By their numbers in this assay, from the lowest: compound 4; then compound 3; then compounds 1 and 2 (each within the scatter of the next).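

In this assay, the hydroxy group of the 4-hydroxycyclohexyl proves dispensable on this aromatic nitrogen: swapping that group for one that keeps the carbon ring, drops to 0 hydrogen-bond donors and adds a second six-membered ring with 2 hetero atoms gives a 2.5-fold lower number from compound 3 to compound 4 (0.40 log units; beyond the scatter). The larger group also stands well clear of the two groups without a ring, with an 81-fold lower number from compound 2 to compound 4 (1.91 log units; beyond the scatter) and a 50-fold lower number from compound 1 to compound 4 (1.70 log units; beyond the scatter), so both ring-bearing compounds sit at lower numbers than both chain compounds, and no compound shown goes against this. No measurement here explains why the number falls with this change.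

From the compounds shown here alone, the hydroxy group leaves and the second ring enters in a single change, so it remains open whether the lower number comes from losing the one, gaining the other, or both. Going by these compounds, how a plain cyclohexyl or a 4-aminocyclohexyl on the same nitrogen would compare with compound 3 and compound 4 also remains open, and either group could help to separate those two contributions.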